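This account rests on a few compounds, and the source may have more. Where it says the series, first, only, none or still open, it means among the compounds named here.

Of the compounds shown here, two have so far been measured in a functional assay on the whole organism (Tail, strain ICR) with Mus musculus as the target, in the tail flick test, with a stated time of 60 min, at a dose of 25 umol/kg by the oral route; on this read-out lower numbers stand for a weaker effect and higher numbers for a stronger effect at the one dose given. Compound 1 `N=C(N)NCCC[C@H](NC(=O)CN(c1ncnc2c1ncn2C1CCCCO1)C1CC1)C(=O)OCc1ccccc1` gives 52.4% in this assay, the higher of the two numbers. Compound 2 `O=C(OCc1ccccc1)[C@@H]1CCCN1C(=O)CN(c1nc(Cl)nc2[nH]cnc12)C1CC1` gives 34.4% in this assay, a number that falls short of compound 1 by a gap beyond the usual scatter of repeated measurements. Compound 3 `CC[C@H](C)[C@H](NC(=O)CN(c1ncnc2c1ncn2C1CCCCO1)C1CC1)C(=O)OCc1ccccc1` has not yet been tested in this assay. It differs from compound 1 in one place: a group of 4 heavy atoms (4 carbon; no ring) in place of a group of 7 heavy atoms (4 carbon, 3 nitrogen; no ring), on a saturated chain carbon bound to an amide-type nitrogen and a carbonyl carbon. Among the measured compounds shown here, no measured pair of compounds shows a change of this kind, so nothing in the numbers says how large an effect it will have; the sec-butyl that enters carries no hydrogen-bond donors, whereas the group that leaves does. A downward step from compound 1 to compound 3 of about a number 17.4 percentage points lower from compound 1 to compound 3 (beyond the scatter) is expected, somewhat beyond the scatter. Compound 3 is therefore estimated at 35%, with a range from 10% to 60%.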

Compound 3, a percentage reported as activity, at one dose (the size of the read-out at that dose, not a potency): 27.4%
The estimate for compound 3 lay 7.6 percentage points above the measured number, within the range that was stated.
By their numbers in this assay, from the lowest: compounds 3 and 2 (each within the scatter of the next); then compound 1.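

Among the compounds shown here, this is the first look at what a change on the saturated chain carbon bound to an amide-type nitrogen and a carbonyl carbon can do: with the rest of the molecule kept the same, putting sec-butyl in place of the nitrogen-containing group gives a number 25 percentage points lower from compound 1 to compound 3 (beyond the scatter) in this assay. The read-out therefore responds to what sits at this place, and in this single pair the higher number belongs to the group with hydrogen-bond donors, which is too little to set a rule. No measurement here explains the drop.

From the compounds shown here alone, it remains open whether the nitrogen atoms matter or simply the size of the group, which a primary amine, a carboxylic acid or a methyl at this place would help to separate. For the compounds shown here, with only one pair, it also remains open whether this step would carry over to another core.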